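Three Stilbene-Type Compounds at the Limit, a Fourth Estimated

A few compounds are considered here, and "the series" means these few. Any claim that something is new, unique, unknown or untested is made for them only; others in the source may bear on it.

Three compounds from this set share a common stilbene-like scaffold with a free phenol, and each was tested in a functional assay on Raji cells (Homo sapiens) for cytotoxicity, with a stated time of 72 h; on this read-out higher numbers stand for an effect only at larger amounts of compound and lower numbers for an effect already at smaller amounts. Compound 1, `C=C[C@@](C)(/C=C/c1ccc(O)cc1)CC/C=C/C(=O)OCC`, carries an ethoxycarbonyl at the end of its side chain. In this assay compound 1 reaches only the limit of > 26000 nM, so no number is known for it. Compound 2, `C=C[C@@](C)(/C=C/c1ccc(O)cc1)CC/C=C/C#N`, carries a cyano at the same position. In this assay compound 2 likewise gives only the limit of > 26000 nM. The change from compound 2 to compound 1 is ethoxycarbonyl in place of cyano on a double-bonded chain carbon bound to a double-bonded chain carbon, and the step it made is a step that the two limits leave unreadable from compound 2 to compound 1.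

Compound 3, `C=C[C@@](C)(/C=C/c1ccc(O)c(/C=C/C#N)c1)CCC=C(C)C`, has a different core; the difference between the two cores of compound 2 and compound 3 is not broken down here. In this assay compound 3 again stands only at the limit of > 26000 nM. Among the measured compounds shown here, the one thing the measurements do show is the limit of > 26000 nM in this assay, at which 3 of the 3 values shown sit.

Compound 4, `C=C[C@@](C)(/C=C/c1ccc(O)c(/C=C/C(=O)OCC)c1)CCC=C(C)C`, is not yet measured. It differs from compound 3 by ethoxycarbonyl in place of cyano on a double-bonded chain carbon bound to a double-bonded chain carbon, which is the same change as that from compound 2 to compound 1. Since that change gave a step that the two limits leave unreadable from compound 2 to compound 1, and all three measured compounds sit at the limit, compound 4 is expected to stay at or near that limit, with an estimated step that the limit leaves unreadable from compound 3 to compound 4. The estimate for compound 4 in this assay is therefore 30000 nM, expected to fall between 12000 nM and 100000 nM, and most likely to be reported only as a limit.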

Compound 4, half-maximal effective concentration: > 26000 nM
Compound 4 gave a limit, no number; the forecaster's own chance of this, stated with the estimate: 85%; the middle value does not contradict the limit.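

In this assay compound 4 gives > 26000 nM, which is a limit and not a number. Compound 3 also stands only at a limit, so no step can be read between compound 3 and compound 4. What the measurements do show is this: the limit of > 26000 nM in this assay, at which 4 of the 4 values shown sit. Left open is what actual number any of the four compounds would give, and whether ethoxycarbonyl in place of cyano changes that number at all.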